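From Cyclopropyl to Octyl on a Shared Core

The source may hold more compounds than are shown below. What is called first, only, known or untested is meant among the compounds shown, and "the series" means these compounds.

Of the compounds shown here, three built on one shared core have been tested in an ADME assay on PC-3 cells (Homo sapiens) for cytotoxicity, read by sulforhodamine B assay, with a stated time of 48 h, tested at 10 uM; a higher number here means more inhibition at the concentration tested (going by the name of the read-out), a lower number less inhibition. Compound 1 `COc1nc2ccc(Br)cc2cc1C(c1ccccc1)n1cc(C2CC2)nn1` gives 22.6%, the highest of the three numbers. Compound 3 `COc1nc2ccc(Br)cc2cc1C(c1ccccc1)n1cc(-c2cccc(F)c2)nn1` gives 14.6%, and the step of a number 8 percentage points lower from compound 1 to compound 3 (within the scatter) stays within the scatter, so these two cannot be told apart. Compound 2 `CCCCCCCc1cn(C(c2ccccc2)c2cc3cc(Br)ccc3nc2OC)nn1` gives 4.42%, and the step of a number 18.2 percentage points lower from compound 1 to compound 2 (beyond the scatter) lies beyond the scatter, as does the step of a number 10.2 percentage points higher from compound 2 to compound 3 (beyond the scatter).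

Compound 4 `CCCCCCCCc1cn(C(c2ccccc2)c2cc3cc(Br)ccc3nc2OC)nn1` has not yet been measured. It differs from compound 1 in a single place: octyl in place of cyclopropyl on an aromatic carbon. An octyl chain is a straight chain closely resembling the heptyl chain of compound 2, so the step of a number 18.2 percentage points lower from compound 1 to compound 2 (beyond the scatter) is the closest guide, while the step to compound 3 concerns a ring-bearing group and bears less on this case. A drop of similar size is therefore expected, and compound 4 is estimated to give 5%, within -4% to 14%. This amounts to an expected step of a number 17.6 percentage points lower from compound 1 to compound 4 (beyond the scatter).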

Compound 4, a percentage reported as inhibition, at one concentration (the size of the read-out at that concentration, not a potency): 2.27%
Estimate against measurement, compound 4: 2.7 percentage points above; the range from low to high includes it.
By their numbers in this assay, from the lowest: compounds 4 and 2 (each within the scatter of the next); then compounds 3 and 1 (each within the scatter of the next).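

Going from heptyl to octyl gives a number 2.2 percentage points lower from compound 2 to compound 4 (within the scatter) in this assay so heptyl and octyl cannot be told apart at this position. Octyl also gives a number 20.3 percentage points lower from compound 1 to compound 4 (beyond the scatter) and a number 12.3 percentage points lower from compound 3 to compound 4 (beyond the scatter) so the low numbers on this aromatic carbon now hold for two straight chains rather than for a single one. Both chains therefore stand apart from cyclopropyl and from 3-fluorophenyl, which cannot themselves be told apart.

Nothing measured here explains the gap between the chains and these two groups. As far as these compounds go, it remains open whether a shorter chain such as ethyl, or an octyl chain ending in an amine or a carboxylic acid, would give a number close to those of the chains or close to that of compound 1.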